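Phosphate aryl exchange on the deprotected nucleotide

A few compounds are considered here, and "the series" means these few. Any claim that something is new, unique, unknown or untested is made for them only; others in the source may bear on it.

Among the compounds with values here, compound 3 `O=c1[nH]c(=O)n([C@H]2C[C@H](O)[C@@H](COP(=O)(O)Oc3ccccc3)O2)cc1F` gives 32200 nM in a functional assay on T98G cells (Homo sapiens) for cytotoxicity, read by MTT assay, with a stated time of 48 h (a higher number here means a weaker inhibitor, a lower number a stronger inhibitor), the highest of the three numbers measured so far; the nearest is compound 2 `O=C(O[C@H]1C[C@H](n2cc(F)c(=O)[nH]c2=O)O[C@@H]1COP(=O)(O)Oc1cccnc1)c1ccccc1` with 1300 nM, and compound 1 `O=C(O[C@H]1C[C@H](n2cc(F)c(=O)[nH]c2=O)O[C@@H]1COP(=O)(O)Oc1ccccc1)c1ccccc1` stands furthest with 810 nM, both gaps beyond the scatter. Compound 4 `O=c1[nH]c(=O)n([C@H]2C[C@H](O)[C@@H](COP(=O)(O)Oc3cccnc3)O2)cc1F` has not been measured. It differs from compound 3 by pyridin-3-yl in place of phenyl on an oxygen. Within the data shown here, one measured step bears directly on this change: a 1.6-fold higher number from compound 1 to compound 2 (0.21 log units; within the scatter), which lies within the scatter. Among the measured compounds shown here, nothing among the measured compounds suggests that the same exchange should read differently when hydrogen rather than benzoyl sits on the other oxygen, although the large step of a 40-fold higher number from compound 1 to compound 3 (1.60 log units; beyond the scatter) shows that this other change dominates the series as it stands. For compound 4 no step beyond the scatter is therefore expected in this assay. The estimated step for compound 4 is a 1.3-fold higher number from compound 3 to compound 4 (0.12 log units; within the scatter). Compound 4 is expected at 42000 nM, with a range from 15000 nM to 120000 nM.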

Compound 4, half-maximal inhibitory concentration: 1200 nM
Compound 4: middle estimate off by 35-fold (1.54 log units), on the high side, outside the stated range (below it).
By their numbers in this assay, from the lowest: compounds 1, 4 and 2 (each within the scatter of the next); then compound 3.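

In this assay, pyridin-3-yl in place of phenyl on an oxygen whose other neighbour is phosphorus has a large effect once hydrogen replaces benzoyl, giving a 27-fold lower number from compound 3 to compound 4 (1.43 log units; beyond the scatter). The size of this exchange therefore depends on the group on the other oxygen: the same change on two cores in this assay, a 1.6-fold higher number (0.21 log units; within the scatter) from compound 1 to compound 2 and a 27-fold lower number (1.43 log units; beyond the scatter) from compound 3 to compound 4, 43-fold (1.63 log units) apart, beyond the scatter of two such steps The reverse reading also holds, since hydrogen in place of benzoyl gives only a 1.1-fold lower number from compound 2 to compound 4 (0.03 log units; within the scatter) when pyridin-3-yl is present, so the large loss belongs to the combination in compound 3 rather than to removal of benzoyl alone: the same change on two cores in this assay, a 40-fold higher number (1.60 log units; beyond the scatter) from compound 1 to compound 3 and a 1.1-fold lower number (0.03 log units; within the scatter) from compound 2 to compound 4, 43-fold (1.63 log units) apart, beyond the scatter of two such steps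

The compounds shown do not tell whether the recovery in compound 4 is specific to pyridin-3-yl or would also appear with pyridin-4-yl or 4-methoxyphenyl on that oxygen. As far as these compounds go, whether acetyl in place of benzoyl would behave in the same way also remains open.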